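Esterifying the acid of compound 2 to give compound 4

The source may hold more compounds than are shown below. What is called first, only, known or untested is meant among the compounds shown, and "the series" means these compounds.

Compound 1, `CC(C)OC(=O)c1cc(CN2CCCC2)c(O)c(CN2CCCC2)c1`: 11.4 ug/mL in a functional assay for inhibition, with Cavia porcellus as the target; a lower number here means that less compound is needed, a higher number that more compound is needed for the effect
Compound 2, `O=C(O)CCc1cc(CN2CCCC2)c(O)c(CN2CCCC2)c1`: > 1000 ug/mL, a limit of this assay rather than a number
Compound 3, `CC(C)COC(=O)CCc1cc(CN2CCCC2)c(O)c(CN2CCCC2)c1`: 14 ug/mL in this assay

Compound 2 stands at the edge of what this assay can report. Its value is only a limit, the point at which (the limit of > 1000 ug/mL in this assay, at which 1 of the 3 values shown sits), so no number is known for it; it is only known that more of compound 2 is needed than of either ester. Compound 4, `CC(C)OC(=O)CCc1cc(CN2CCCC2)c(O)c(CN2CCCC2)c1`, differs from compound 2 in a single place: isopropyl in place of hydrogen on an oxygen next to a carbonyl group.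

Going by the values given here, one measured step bears directly on this change. Putting an isobutyl group on the same oxygen gave an at least 71-fold lower number from compound 2 to compound 3 (1.85 log units; beyond the scatter). A second comparison shows that the two esters already measured behave alike: a 1.2-fold higher number from compound 1 to compound 3 (0.09 log units; within the scatter). Replacing hydrogen with isopropyl rather than isobutyl is therefore expected to recover the same large drop, and compound 4 is expected to show an at least 76-fold lower number from compound 2 to compound 4 (1.88 log units; beyond the scatter). Compound 4 is estimated at 13 ug/mL, with a likely range from 6 ug/mL to 30 ug/mL.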

Compound 4, concentration for half-maximal effect: 4 ug/mL
Compound 4: middle estimate off by 3.3-fold (0.51 log units), on the high side; measured number below the stated range.
By their numbers in this assay, from the lowest: compound 4; then compounds 1 and 3 (each within the scatter of the next). At a limit, above all of these: compound 2.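

Against compound 2, whose value in this assay is a limit and not a number, the isopropyl ester gives an at least 250-fold lower number from compound 2 to compound 4 (2.39 log units; beyond the scatter), so the ester's gain over the acid has only a minimum size and no exact one. The earlier esters could not show whether the alkyl group on this oxygen matters, as compounds 1 and 3 differ in more than that group, but the direct swap of isobutyl for isopropyl on the same chain gives a 3.5-fold lower number from compound 3 to compound 4 (0.54 log units; beyond the scatter), so the choice of alkyl group does change the number. Moving from the isopropoxycarbonyl group on the aromatic carbon to the 2-(isopropoxycarbonyl)ethyl group gives a 2.9-fold lower number from compound 1 to compound 4 (0.45 log units; beyond the scatter), which leaves compound 4 with the lowest number of the four, with each of its steps beyond the scatter.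

With only isobutyl and isopropyl compared on this chain, the trend among alkyl groups rests on a single pair. Going by these compounds, whether a methyl or tert-butyl ester would go lower still remains open, as does what an amide in place of the ester, or a longer chain between the ester and the aromatic carbon, would do.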